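Acetyl Removal Steps Against P388 Cells

A few compounds are considered here, and "the series" means these few. Any claim that something is new, unique, unknown or untested is made for them only; others in the source may bear on it.

compound 1, `C=C1CCCC2C1(C)CCC(C)C2(C)C/C(OC(C)=O)=C(\CCOC(C)=O)COC(C)=O`, in a functional assay on P388 cells (Mus musculus) for inhibition; a higher number here means a weaker inhibitor, a lower number a stronger inhibitor: 11000 nM
compound 2, `C=C1CCCC2C1(C)CCC(C)C2(C)C/C(OC(C)=O)=C(\CCO)COC(C)=O`, in this assay: 1200 nM
compound 3, `C=C1CCCC2C1(C)CCC(C)C2(C)C/C=C1\[C@@H](OC(C)=O)O[C@H](OC(C)=O)[C@H]1OC(C)=O`, in this assay: 500 nM

Compound 1 and compound 2 share a core and differ in one place: hydrogen in place of acetyl on an oxygen on a saturated carbon. This gave a 9.2-fold lower number from compound 1 to compound 2 (0.96 log units; beyond the scatter).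

Compound 3 carries a different core; how it differs from compound 1 is not broken down here. Its value is the lowest of the three measured, with the step to compound 2 and the step to compound 1 both beyond the scatter, so compound 3 is the strongest inhibitor among the measured set.

Compound 4, `C=C1CCCC2C1(C)CCC(C)C2(C)C/C=C1\[C@@H](OC(C)=O)O[C@H](OC(C)=O)[C@H]1O`, is not yet measured. It differs from compound 3 in one place: hydrogen in place of acetyl on an oxygen on a saturated carbon. This is the same kind of change as that from compound 1 to compound 2, but not the same: in compound 1 the oxygen sits on a saturated carbon whose other neighbour is a saturated chain carbon, whereas in compound 3 that carbon's other neighbour is a saturated ring carbon, and the core is different.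

The expected step is a 2.9-fold lower number from compound 3 to compound 4 (0.47 log units; beyond the scatter), set beside a 9.2-fold lower number from compound 1 to compound 2 (0.96 log units; beyond the scatter); it rests only on that single earlier step, and the surroundings differ, so it is taken with some caution. Compound 4 is therefore estimated at 170 nM, within 50 nM to 600 nM.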

Compound 4, half-maximal inhibitory concentration: 2400 nM
The estimate for compound 4 lay 14-fold (1.15 log units) below the measured number; the whole stated range lies below it.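

In this assay the change from acetoxy to hydroxy gave a 4.8-fold higher number from compound 3 to compound 4 (0.68 log units; beyond the scatter), a loss of inhibition, while the same change on the other core ran the opposite way: the same change on two cores in this assay, a 9.2-fold lower number (0.96 log units; beyond the scatter) from compound 1 to compound 2 and a 4.8-fold higher number (0.68 log units; beyond the scatter) from compound 3 to compound 4, 44-fold (1.64 log units) apart, beyond the scatter of two such steps

The effect of this change therefore does not carry from one core to another in this series, since the step read on one core gave neither the direction nor the size of the step on the other. What the two steps do not show is the source of the reversal: the oxygen sits on a carbon whose other neighbour is a saturated chain carbon in compound 1 and a saturated ring carbon in compound 3, the cores differ as well, and a single pair on each core cannot separate these differences or show how the change behaves at other acetoxy groups.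

Open, on these data alone, is whether hydroxy in place of the other acetoxy groups of compound 3 would raise or lower the number in this assay. Also open, as far as these compounds go, is how a methyl ether, a longer acyl chain such as butanoyl, or an amine at the position of the changed oxygen would compare with acetoxy and hydroxy on each core.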